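This account rests on a few compounds, and the source may have more. Where it says the series, first, only, none or still open, it means among the compounds named here.

Measured so far:
- compound 1 `COc1cccc(CCC(=O)Nc2nc3ccccc3c(=O)s2)c1` — in an assay on membranes from brain for displacement of a labelled ligand from adenosine receptor A1 (Rattus norvegicus), read by scintillation counting, with a stated time of 90 min (on this read-out lower numbers stand for stronger inhibition and higher numbers for weaker inhibition), compound 1 gives 367 nM
- compound 2 `COc1cccc(/C=C/CC(=O)Nc2nc3ccccc3c(=O)s2)c1` — in this assay compound 2 gives 11.2 nM

Compound 1 stands at the higher of the two numbers in this assay, that is the weaker of the two; compound 2 sits well below it, and the two values lie clearly apart. Among the compounds with values here, no single-change pair between measured compounds is available, so nothing shows how the aryl group alone moves the number.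

Compound 3 `O=C(CCc1ccc(Cl)c(Cl)c1)Nc1nc2ccccc2c(=O)s1` is the next compound for this assay. Relative to compound 1 the change is 3,4-dichlorophenyl in place of 3-methoxyphenyl on a saturated chain carbon, two bonds along the chain from a carbonyl carbon. The shared core and the saturated chain of compound 1 are kept, so compound 1 is the reference. Within the data shown here, with no measured pair to lean on, the step of a 1.3-fold lower number from compound 1 to compound 3 (0.12 log units; within the scatter) is expected to be small, not beyond the scatter, in either direction. Compound 3 is therefore estimated at 280 nM, within 60 nM to 1300 nM.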

Compound 3, inhibition constant: > 1500 nM
Compound 3 was reported as a limit; the forecaster's own chance of this, stated with the estimate: 5%; middle value at least 5.3-fold (0.72 log units) from the limit.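

In this assay compound 3 gives > 1500 nM, which is a limit of the assay and not a number. Within the data shown here, the aryl group on a saturated chain carbon, two bonds along the chain from a carbonyl carbon, is therefore not a neutral place to make changes: 3,4-dichlorophenyl in place of 3-methoxyphenyl gives an at least 4.0-fold higher number from compound 1 to compound 3 (0.61 log units; beyond the scatter), the first single-place step. From the compounds shown here alone, its true size stays unknown on the upper side, as the reading for compound 3 is only this: the limit of > 1500 nM in this assay, at which 1 of the 3 values shown sits.

Still open, going by these compounds, is whether the loss of the methoxy group or the entry of the two chlorines carries the step, which an unsubstituted phenyl or a monochlorophenyl group at this place could separate. Also open, on these data alone, is whether 3,4-dichlorophenyl has a comparable effect on the unsaturated chain of compound 2.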